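Removing bromo from compound 1: expected outcome

A few compounds are considered here, and "the series" means these few. Any claim that something is new, unique, unknown or untested is made for them only; others in the source may bear on it.

Measured so far:
Compound 1, `C=C1C[C@]23C[C@@]1(O)CC[C@H]2c1ccc(OS(=O)(=O)c2ccc(C)cc2)c(C)c1[C@@H]3Cn1cc(-c2ccc(Br)cc2)nn1`, gives > 20000 nM in a functional assay on HL-60 cells (Homo sapiens) for cytotoxicity, read by MTT assay, with a stated time of 4 days; on this read-out lower numbers stand for stronger inhibition and higher numbers for weaker inhibition; this is a limit of the assay, not a number.
Compound 2, `Cc1c(O)ccc2c1[C@H](Cn1cc(-c3ccccc3)nn1)[C@@]13CC(=O)[C@@](C)(CC[C@@H]21)C3`, gives > 20000 nM in this assay; again a limit.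
Compound 3, `C=C1C[C@]23C[C@@]1(O)CC[C@H]2c1cc(Br)c(O)c(C)c1[C@@H]3Cn1cc(-c2ccccc2)nn1`, gives > 20000 nM in this assay; again a limit.

Compound 1 therefore stands where every measured compound stands: at the limit, with no numeric value to compare (the limit of > 20000 nM in this assay, at which 3 of the 3 values shown sit). Within the data shown here, nothing among the measured compounds separates one from another, so no measured step exists on which to build.

Compound 4, `C=C1C[C@]23C[C@@]1(O)CC[C@H]2c1ccc(OS(=O)(=O)c2ccc(C)cc2)c(C)c1[C@@H]3Cn1cc(-c2ccccc2)nn1`, is derived from compound 1 by the change (hydrogen in place of bromo on an aromatic carbon). With all three measured compounds sitting at the limit, the step expected from compound 1 to compound 4 is none beyond the usual scatter, and most probably compound 4 will also be reported only as a limit.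

For compound 4 the estimate is 25000 nM, within 10000 nM to 60000 nM, which means an expected step that the limit leaves unreadable from compound 1 to compound 4.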

Compound 4, half-maximal inhibitory concentration: > 20000 nM
Compound 4: only a limit was reported; the forecaster's own chance of this, stated with the estimate: 85%; the middle value lies beyond the limit too.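

No step can be read from compound 1 to compound 4, since both values are limits and not numbers: the limit of > 20000 nM in this assay, at which 4 of the 4 values shown sit.
The compounds shown leave open whether any member of this series gives a numeric value, and what replacing 4-bromophenyl with phenyl does on the read-out.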